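Thiazole amide variant of a benzimidazole rhodanine-like series

The source may report more compounds than this note shows. Statements on the series, on what has been measured and on what is new or still open speak of the compounds shown alone.

Measured compounds:
compound 1 `Cn1c(/C=C2\SC(=O)N(CC(=O)Nc3cc(C(C)(C)C)on3)C2=O)nc2ccccc21` 15300 nM
compound 2 `CCn1c(/C=C2\SC(=O)N(CC(=O)Nc3cc(C(C)(C)C)on3)C2=O)nc2ccccc21` 44800 nM

For the measured compounds named here, in a functional assay on A549 cells (Homo sapiens) for inhibition, read by MTT assay, with a stated time of 48 h (on this read-out lower numbers stand for stronger inhibition and higher numbers for weaker inhibition), compound 1 gives the lower of the two numbers; the step of a 2.9-fold higher number from compound 1 to compound 2 (0.47 log units; beyond the scatter) is the only measured change, and it concerns the chain on the aromatic nitrogen. Compound 3 `Cn1c(/C=C2\SC(=O)N(CC(=O)Nc3nc(-c4ccccc4)cs3)C2=O)nc2ccccc21` instead differs from compound 1 by 4-phenyl-1,3-thiazol-2-yl in place of 5-(tert-butyl)-1,2-oxazol-3-yl on an amide-type nitrogen. Going by the values given here, no measured step touches that amide-type nitrogen, so the size of the change there is unknown. Compound 3 is therefore expected near compound 1, with the step of a 1.0-fold lower number from compound 1 to compound 3 (0.01 log units; within the scatter) not beyond the scatter. The estimate for compound 3 is 15000 nM, within 4000 nM to 60000 nM.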

Compound 3, half-maximal inhibitory concentration: 11500 nM
Compound 3: middle estimate off by 1.3-fold (0.12 log units), on the high side, and the stated range covers the measured number.
By their numbers in this assay, from the lowest: compounds 3 and 1 (each within the scatter of the next); then compound 2.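

The amide-type nitrogen now has its first reading in this assay: there is a 1.3-fold lower number from compound 1 to compound 3 (0.12 log units; within the scatter) and so 4-phenyl-1,3-thiazol-2-yl and 5-(tert-butyl)-1,2-oxazol-3-yl cannot be told apart here. This holds even though the entering group carries an added six-membered aromatic ring of carbon only, whereas the earlier pair spoke only to the chain on the aromatic nitrogen. No supporting data explain this result.

Open, as far as these compounds go, is how a 1,3-thiazol-2-yl without the phenyl, or with a carboxylic acid on the phenyl, would read at this nitrogen. Also open, from the compounds shown here alone, is whether the longer chain on the aromatic nitrogen would give a similar step alongside 4-phenyl-1,3-thiazol-2-yl.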